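A few compounds are considered here, and "the series" means these few. Any claim that something is new, unique, unknown or untested is made for them only; others in the source may bear on it.

Measured compounds in this set:

Compound 1, `C[C@H]1[C@H](NCc2sccc2-c2ccccc2)C[C@H]2C[C@@H]1C2(C)C`: 12500 nM
Compound 2, `C[C@H]1[C@H](NCc2cccs2)C[C@H]2C[C@@H]1C2(C)C`: 25000 nM
Compound 3, `C[C@H]1[C@H](NCc2ccc(-c3ccc(Br)s3)s2)C[C@H]2C[C@@H]1C2(C)C`: 780 nM

In an ADME assay on MDCK cells (Canis lupus familiaris) for cytotoxicity, read by microscopy, with a stated time of 48 h (on this read-out lower numbers stand for higher toxicity in this test and higher numbers for lower toxicity in this test), compound 2 stands at the highest of the three numbers. The step of a 2.0-fold higher number from compound 1 to compound 2 (0.30 log units; within the scatter) lies within the scatter, so compound 2 and compound 1 cannot be told apart on this read-out, whereas the step of a 32-fold lower number from compound 2 to compound 3 (1.51 log units; beyond the scatter) is large and well beyond the scatter.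

Compound 4, `C[C@H]1[C@H](NCc2cc(C3CCCC3)cs2)C[C@H]2C[C@@H]1C2(C)C`, is not yet measured. It differs from compound 2 in one place: cyclopentyl in place of hydrogen on an aromatic carbon.

Among the measured compounds shown here, two measured steps bear on this change, both of them replacing hydrogen on an aromatic carbon of the shared core with a larger group. The phenyl case, a 2.0-fold higher number from compound 1 to compound 2 (0.30 log units; within the scatter) read in reverse, did not move the number beyond the scatter. The 5-bromothiophen-2-yl case, a 32-fold lower number from compound 2 to compound 3 (1.51 log units; beyond the scatter), moved it strongly toward higher toxicity. Cyclopentyl is a non-aromatic group of five carbons, without the bromine or the second sulfur of compound 3, so the outcome is expected to fall between these two cases, a modest move toward a lower number.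

Compound 4 is therefore estimated at 8000 nM, with a range from 2000 nM to 25000 nM. That estimate means a step of a 3.1-fold lower number from compound 2 to compound 4 (0.49 log units; beyond the scatter), expected to sit near the edge of the scatter rather than to repeat the large drop seen for compound 3 because of a 32-fold lower number from compound 2 to compound 3 (1.51 log units; beyond the scatter).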

Compound 4, minimum cytotoxic concentration: 1560 nM
Estimate against measurement, compound 4: 5.1-fold (0.71 log units) above, outside the stated range (below it).
By their numbers in this assay, from the lowest: compounds 3 and 4 (each within the scatter of the next); then compounds 1 and 2 (each within the scatter of the next).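

In this assay the cyclopentyl group, on an aromatic carbon two ring bonds from the ring sulfur, gives a 16-fold lower number from compound 2 to compound 4 (1.20 log units; beyond the scatter) and so brings a large move toward higher toxicity in this test without the bromine or the second sulfur that compound 3 carries. Among the compounds shown here, the step of a 32-fold lower number from compound 2 to compound 3 (1.51 log units; beyond the scatter) is therefore no longer the only large drop from compound 2, although compound 1 goes against any rule that a large group on this ring lowers the number, with a 2.0-fold higher number from compound 1 to compound 2 (0.30 log units; within the scatter) lying within the scatter. Nothing given here accounts for the size of the drop with cyclopentyl, or for the difference from the phenyl case.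

The compounds shown leave open whether the drop follows cyclopentyl itself or this ring carbon, as no single group appears here on more than one ring carbon. They also leave open how the number would respond to a methyl group, a longer chain such as hexyl, or an amine or a carboxylic acid on the same carbon, and so whether any group there keeps the number near that of compound 2.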